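The source may report more compounds than this note shows. Statements on the series, on what has been measured and on what is new or still open speak of the compounds shown alone.

Compound 1, `C=CCOc1nc(N)nc2c1ncn2/C=C1/CC1(CO)CO`, in an ADME assay on HFF cells (Homo sapiens) for cytotoxicity, with a stated time of 8 days (a higher number here means that more compound is tolerated, a lower number that less compound is tolerated), gives > 300000 nM, which is a limit of the assay rather than a number.
Compound 2, `Nc1nc(NC2CC2)c2ncn(/C=C3/CC3(CO)CO)c2n1`, in this assay gives > 300000 nM, again a limit.
Compound 3, `CSc1nc(N)nc2c1ncn2/C=C1/CC1(CO)CO`, in this assay gives > 300000 nM, once more a limit.

Compound 3 therefore stands at the top of what this assay can report, and so do the other two measured compounds (the limit of > 300000 nM in this assay, at which 3 of the 3 values shown sit). The steps that exchange the group on the aromatic carbon are all unreadable for the same reason: a step that the two limits leave unreadable from compound 1 to compound 3, a step that the two limits leave unreadable from compound 2 to compound 3 and a step that the two limits leave unreadable from compound 1 to compound 2. None of them touches the methylsulfanyl group itself.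

Compound 4, `Nc1nc(SCc2ccccc2)c2ncn(/C=C3/CC3(CO)CO)c2n1`, differs from compound 3 by phenyl in place of hydrogen on a saturated chain carbon bound to a sulfur. For the measured compounds named here, no measured pair shows a phenyl entering on a saturated chain carbon bound to a sulfur, so the measured steps give no size for this change, only the observation that every variation at that aromatic carbon so far has left the value at the limit. The step from compound 3 to compound 4 is thus expected to be a number no higher from compound 3 to compound 4 (the limit leaves the size open), most likely unreadable again. Compound 4 is estimated at 300000 nM, within 50000 nM to 1000000 nM.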

Compound 4, half-maximal cytotoxic concentration: > 300000 nM
Compound 4 was reported as a limit; the forecaster's own chance of this, stated with the estimate: 60%; the middle value lies on the limit itself.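

Compound 4 also gives only a limit, so its steps from compound 1, compound 2 and compound 3 cannot be read: the limit of > 300000 nM in this assay, at which 4 of the 4 values shown sit.
The compounds shown leave open how far each lies past that limit in this assay and which change on the shared core, if any, would bring a readable number.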